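Swapping Morpholine for Piperidine in Two Related Series

The source may report more compounds than this note shows. Statements on the series, on what has been measured and on what is new or still open speak of the compounds shown alone.

Measured so far:
compound 1 `COc1ccc2oc(CSC(=S)N3CCOCC3)cc(=O)c2c1`: > 25000 nM, a limit of the assay
compound 2 `O=c1c(CSC(=S)N2CCOCC2)coc2cc(Cl)ccc12`: 8100 nM
compound 3 `COc1ccc2oc(CSC(=S)N3CCCCC3)cc(=O)c2c1`: 10000 nM

All three were tested in a functional assay on MCF7 cells (Homo sapiens) for antiproliferative activity, read by MTT assay, with a stated time of 72 h; a higher number here means a weaker inhibitor, a lower number a stronger inhibitor. Compound 1 gives only a limit there: the limit of > 25000 nM in this assay, at which 1 of the 3 values shown sits. Compound 3 differs from compound 1 by piperidin-1-yl in place of morpholin-4-yl on a thiocarbonyl carbon, and this change produced an at least 2.5-fold lower number from compound 1 to compound 3 (0.39 log units; beyond the scatter). Compound 2 carries the same morpholine group as compound 1 but sits on a different core; the difference between the two cores is not broken down here. Compound 2 and compound 3 give values within the scatter of each other.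

Compound 4 `O=c1c(CSC(=S)N2CCCCC2)coc2cc(Cl)ccc12` has not yet been measured. It stands to compound 2 as compound 3 stands to compound 1: piperidin-1-yl in place of morpholin-4-yl on a thiocarbonyl carbon. Since the place is the same, this is the same change, and a step in the same direction is expected. Its size is uncertain because the earlier step starts from a limit (the limit of > 25000 nM in this assay, at which 1 of the 3 values shown sits), so only a lower bound on it is known.

From compound 2 to compound 4 in this assay a step of a 2.0-fold lower number from compound 2 to compound 4 (0.31 log units; beyond the scatter) is expected. Compound 4 is estimated at 4000 nM, expected to fall between 1500 nM and 12000 nM.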

Compound 4, half-maximal inhibitory concentration: 380 nM
Compound 4: middle estimate off by 11-fold (1.02 log units), on the high side; the measured number lies below the stated range.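

In this assay, the swap of morpholin-4-yl for piperidin-1-yl on the thiocarbonyl carbon gives a 21-fold lower number from compound 2 to compound 4 (1.33 log units; beyond the scatter), a large step on the core of compound 2. The direction of the change therefore carries over between the two cores shown, though two cores are too few to make it a general rule for the series, and the two steps compare as follows: the same change on two cores in this assay, an at least 2.5-fold lower number (0.39 log units; beyond the scatter) from compound 1 to compound 3 and a 21-fold lower number (1.33 log units; beyond the scatter) from compound 2 to compound 4; the limit leaves it open whether they differ Whether the size of the step also carries over stays unsettled, because the value of compound 1 is only a limit of the assay and not a number: the limit of > 25000 nM in this assay, at which 1 of the 4 values shown sits.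

The compounds shown leave open whether other amines on the thiocarbonyl carbon, such as pyrrolidine or open-chain diethylamine, would behave like piperidine. They also leave open how the step would look on a core bearing another group, such as a fluoro group in place of the chlorine of compound 2.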